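Methyl in place of nitro: an open question

The source may hold more compounds than are shown below. What is called first, only, known or untested is meant among the compounds shown, and "the series" means these compounds.

Compound 1 `COc1cc(-c2nccn3cc(-c4ccc5[nH]ccc5c4)nc23)cc(OC)c1OC` gives 23 nM
Compound 2 `COc1cc(-c2nccn3cc(-c4ccc([N+](=O)[O-])cc4)nc23)cc(OC)c1OC` gives > 10000 nM
Compound 3 `COc1cc(-c2nccn3cc(-c4ccc(C)cc4)nc23)cc(OC)c1OC` is not yet measured

In a functional assay on HCT-116 cells (Homo sapiens) for inhibition, read by MTT assay, with a stated time of 48 h (on this read-out lower numbers stand for stronger inhibition and higher numbers for weaker inhibition), compound 2 gives > 10000 nM as a limit of the assay and not a number. Compound 3 carries methyl in place of nitro on an aromatic carbon, para to a large group (methyl in place of nitro on an aromatic carbon). Within the data shown here, only one measured step bears on this place, and it is large: an at least 430-fold higher number from compound 1 to compound 2 (2.63 log units; beyond the scatter) beyond the scatter. That step fixes no exact size for the change at hand. The expected step is an at least 6.6-fold lower number from compound 2 to compound 3 (0.82 log units; beyond the scatter) by estimate, toward a lower number. Compound 3 is estimated at 1500 nM (expected range 200 nM to 10000 nM).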

Compound 3, half-maximal inhibitory concentration: 74 nM
The estimate for compound 3 lay 20-fold (1.31 log units) above the measured number; measured number below the stated range.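

Losing the 1H-indol-5-yl group does not by itself cost most of the activity, since the 4-methylphenyl group gives only a 3.2-fold higher number from compound 1 to compound 3 (0.51 log units; beyond the scatter). The heavy loss in compound 2 therefore goes with nitro at this place, as methyl in its place gives an at least 130-fold lower number from compound 2 to compound 3 (2.13 log units; beyond the scatter). That step is only a bound, as compound 2 gives a limit of the assay and not a number: the limit of > 10000 nM in this assay, at which 1 of the 3 values shown sits.

Going by these compounds, it remains open whether an amine or a carboxylic acid at this place would behave like methyl or like nitro. A longer chain such as ethyl or propyl is equally unresolved.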